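Urea aryl substituent: methyl to isopropyl

The source may hold more compounds than are shown below. What is called first, only, known or untested is meant among the compounds shown, and "the series" means these compounds.

Two compounds of the series have numbers in a functional assay on Shh Light II cells (Mus musculus) for inhibition, read by a luciferase reporter; a lower number here means a stronger inhibitor, a higher number a weaker inhibitor. Compound 1, `C[C@H]1C[C@H](c2nc(-c3ccc4ccccc4n3)no2)CCN1C(=O)Nc1ccccc1Cl`, gives 900 nM. Compound 2, `Cc1ccccc1NC(=O)N1CCC(c2nc(-c3ccc4ccccc4n3)no2)CC1`, gives 440 nM, the lowest of the two numbers; the number for compound 1 stands higher by a margin beyond the usual scatter. Compound 1 and compound 2 differ in more than one place, so their gap says nothing about any single change.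

Compound 3, `CC(C)c1ccccc1NC(=O)N1CCC(c2nc(-c3ccc4ccccc4n3)no2)CC1`, has not been measured. Its difference from compound 2: isopropyl in place of methyl on an aromatic carbon. Within the data shown here, no measured pair isolates this kind of change, so the direction of the step rests on no number in hand. In this assay the expected step is a 1.1-fold higher number from compound 2 to compound 3 (0.06 log units; within the scatter), small and quite possibly within the scatter, in either direction. Compound 3 is estimated at 500 nM, with a range from 200 nM to 1500 nM.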

Compound 3, half-maximal inhibitory concentration: 480 nM
The estimate for compound 3 lay 1.0-fold (0.02 log units) above the measured number; low and high end bracket the measured number.
By their numbers in this assay, from the lowest: compounds 2, 3 and 1 (each within the scatter of the next, the first and the last beyond it).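

In this assay the change from 2-methylphenyl to 2-isopropylphenyl gives a 1.1-fold higher number from compound 2 to compound 3 (0.04 log units; within the scatter) and so stays within the scatter: this aromatic carbon, ortho to a large group, accepts isopropyl in place of methyl with no measurable change in the number. Among these compounds, this is the first step that isolates a single change, since the gap between compound 1 and compound 2 spans more than one place. Nothing measured here accounts for the two numbers lying so close.

Going by these compounds, whether the same holds for an amine, a carboxylic acid or a longer chain on this aromatic carbon stays open. Compound 1 carries chloro on the same aromatic ring but differs from compound 2 in more than one place, so the effect of chloro against methyl remains unseparated.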